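Aryl replacement on the hydrazone of the shared core

The source may report more compounds than this note shows. Statements on the series, on what has been measured and on what is new or still open speak of the compounds shown alone.

Compound 1 `Cc1cccc(/C=N/Nc2ncc3c(n2)n(C2CCCC2)c(=O)c(=O)n3C)c1` is the reference point of this small set. In a functional assay on A549 cells (Homo sapiens) for antiproliferative activity, read by MTT assay (on this read-out lower numbers stand for stronger inhibition and higher numbers for weaker inhibition), compound 1 gives 34500 nM, the highest number among the three measured compounds. Compound 2 `Cn1c(=O)c(=O)n(C2CCCC2)c2nc(N/N=C/c3ccc(F)cc3Cl)ncc21` gives 11000 nM, and compound 3 `Cn1c(=O)c(=O)n(C2CCCC2)c2nc(N/N=C/c3ccc(F)cc3Br)ncc21` gives 6590 nM. Replacing the 3-methylphenyl brings a 3.1-fold lower number from compound 1 to compound 2 (0.50 log units; beyond the scatter) and, with the bromo analogue, a 5.2-fold lower number from compound 1 to compound 3 (0.72 log units; beyond the scatter). The halogen swap alone shows a 1.7-fold lower number from compound 2 to compound 3 (0.22 log units; within the scatter), so the two halogenated compounds cannot be ordered against each other.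

Compound 4 `Cn1c(=O)c(=O)n(C2CCCC2)c2nc(N/N=C/c3cc([N+](=O)[O-])ccc3Cl)ncc21` has not yet been measured. Against compound 1 the change is 2-chloro-5-nitrophenyl in place of 3-methylphenyl on a carbon with a double bond to nitrogen. The step from compound 1 to compound 2 is the closest guide, as compound 2 also carries a chloro-bearing ring in place of the 3-methylphenyl; that step was a modest lowering of the number, beyond the scatter. Going by the values given here, the nitro group has no precedent in the measured compounds, so its own contribution is unknown. A lowering of similar size to a 3.1-fold lower number from compound 1 to compound 2 (0.50 log units; beyond the scatter) is therefore expected, with a wide range. Compound 4 is expected to give 11000 nM in this assay, between 4000 nM and 30000 nM. This estimate means an expected 3.1-fold lower number from compound 1 to compound 4 (0.50 log units; beyond the scatter).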

Compound 4, half-maximal inhibitory concentration: 8780 nM
For compound 4 the middle estimate is 1.3-fold (0.10 log units) above the measured one; the measured number falls inside the stated range.
By their numbers in this assay, from the lowest: compounds 3, 4 and 2 (each within the scatter of the next); then compound 1.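

At the carbon with a double bond to nitrogen, the lowering in this assay is not confined to the two halogen-bearing fluorophenyl rings: 2-chloro-5-nitrophenyl in place of 3-methylphenyl also gives a step beyond the scatter, with a 3.9-fold lower number from compound 1 to compound 4 (0.59 log units; beyond the scatter). The three substituted rings form one group that this read-out cannot resolve, as shown by a 1.3-fold lower number from compound 2 to compound 4 (0.10 log units; within the scatter) and a 1.3-fold higher number from compound 3 to compound 4 (0.12 log units; within the scatter), so exchanging the fluoro for a nitro group at a different ring position leaves no distinguishable mark on the number. No measurement at hand accounts for the step away from 3-methylphenyl.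

Compounds 2, 3 and 4 all carry a halogen on the ring while compound 1 has none, so the share of the chloro or bromo in the step remains unseparated from that of the other ring substituents and from the loss of the methyl group. Still open, going by these compounds, is how an unsubstituted phenyl, or a ring bearing a dimethylamino group or a carboxylic acid, would read at this place.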